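A few compounds are considered here, and "the series" means these few. Any claim that something is new, unique, unknown or untested is made for them only; others in the source may bear on it.

Measured so far in a physicochemical assay for lipophilicity; on this read-out lower numbers stand for lower lipophilicity and higher numbers for higher lipophilicity:
- compound 1 `Cc1nc(-c2cc(C(F)(F)F)ccc2[C@H]2CCOc3cc(S(=O)(=O)Nc4cccc(F)n4)ccc32)co1` gives 4
- compound 2 `O=S(=O)(Nc1nccs1)c1ccc2c(c1)OCC[C@H]2c1ccc(C(F)(F)F)cc1-c1nccs1` gives 3.3
- compound 3 `O=S(=O)(Nc1ncccn1)c1ccc2c(c1)CC[C@@H]2c1ccc(C(F)(F)F)cc1-c1ccc(F)nc1` gives 3.2

Compound 3 at 3.2 stands at the low end of these numbers. It is level, within the scatter, with compound 2 at 3.3 and clearly apart from compound 1 at 4 on this scale.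

The next compound to be measured is compound 4 `Cn1nccc1-c1cc(C(F)(F)F)ccc1[C@H]1CCc2cc(S(=O)(=O)Nc3ncccn3)ccc21` which carries 1-methyl-1H-pyrazol-5-yl in place of 6-fluoropyridin-3-yl on an aromatic carbon, ortho to a large group and meta to a trifluoromethyl group. The counted change is 1-methyl-1H-pyrazol-5-yl in place of 6-fluoropyridin-3-yl on an aromatic carbon and nothing else differs.

For the measured compounds named here, no two measured compounds differ in one place only, so the data offer no direct precedent for this swap, and the expectation below is correspondingly loose. It starts from compound 3 at 3.2 as the anchor. The expected move is downward, with a number 0.40 log units lower from compound 3 to compound 4 (beyond the scatter) as the estimated step, modestly beyond the scatter. Compound 4 is expected at 2.8 with an estimated range of 2.3 to 3.3 on this scale.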

Compound 4, distribution coefficient: 2.4
Estimate against measurement, compound 4: 0.40 log units above; the measured number falls inside the stated range.
By their numbers in this assay, from the lowest: compound 4; then compounds 3 and 2 (each within the scatter of the next); then compound 1.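

At the aromatic carbon ortho to a large group and meta to a trifluoromethyl group, the set now holds its first change that can be read on its own: in this assay, 1-methyl-1H-pyrazol-5-yl in place of 6-fluoropyridin-3-yl gives a number 0.80 log units lower from compound 3 to compound 4 (beyond the scatter) on an otherwise unchanged structure. The read-out at this position therefore depends on which aromatic ring sits there, here a five-membered ring with two hetero atoms against a six-membered ring with one. No measurement shown accounts for the step.

This single step cannot separate the contribution of the ring itself from that of its methyl group. It also leaves open what a primary amine or a carboxylic acid on this carbon would give, and whether the step would carry over to the core of compound 1 or compound 2.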